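The source may report more compounds than this note shows. Statements on the series, on what has been measured and on what is new or still open speak of the compounds shown alone.

Compounds here share one core and differ only in the aryl group attached to a carbon with a double bond to nitrogen. Compound 1 `COc1ccc(/C=N/NC(=O)Nc2ccc(Oc3ccnc(-c4nncn4CCN(C)C)c3)c(F)c2)c(OC)c1OC` gives 7650 nM in a functional assay on U-87MG ATCC cells (Homo sapiens) for cytotoxicity, read by MTT assay, with a stated time of 72 h; on this read-out lower numbers stand for stronger inhibition and higher numbers for weaker inhibition. Compound 2 `COc1cc(/C=N/NC(=O)Nc2ccc(Oc3ccnc(-c4nncn4CCN(C)C)c3)c(F)c2)cc(OC)c1OC` gives 22500 nM in this assay. Compound 3 `CN(C)CCn1cnnc1-c1cc(Oc2ccc(NC(=O)N/N=C/c3cccc(Cl)c3Cl)cc2F)ccn1` gives 13200 nM in this assay, the second highest of the three numbers, though its gaps to compound 1 and to compound 2 both lie within the scatter.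

The measured steps all swap groups at this same position: a 2.9-fold higher number from compound 1 to compound 2 (0.47 log units; beyond the scatter), a 1.7-fold higher number from compound 1 to compound 3 (0.24 log units; within the scatter) and a 1.7-fold lower number from compound 2 to compound 3 (0.23 log units; within the scatter). The largest of them is modest, and the other two lie within the scatter, so this position has so far tolerated quite different aryl groups with little movement in the numbers.

Compound 4 `CN(C)CCn1cnnc1-c1cc(Oc2ccc(NC(=O)N/N=C/c3cc(Br)c(O)c(Br)c3)cc2F)ccn1` carries the change (3,5-dibromo-4-hydroxyphenyl in place of 2,3-dichlorophenyl on a carbon with a double bond to nitrogen). Within the data shown here, none of the measured compounds bears a hydroxy group or bromine here, so there is no direct precedent for this particular group. Given the small movements seen for every swap at this position, the expected step of a 1.0-fold lower number from compound 3 to compound 4 (0.01 log units; within the scatter) is none beyond the scatter. Compound 4 is therefore estimated at 13000 nM in this assay, within a range from 5000 nM to 35000 nM.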

Compound 4, half-maximal inhibitory concentration: > 100000 nM
Compound 4 gave a limit, no number (the forecaster's own chance of this, stated with the estimate: 5%); middle value at least 7.6-fold (0.88 log units) from the limit.
By their numbers in this assay, from the lowest: compounds 1, 3 and 2 (each within the scatter of the next, the first and the last beyond it). At a limit, above all of these: compound 4.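

Compound 4 gives a limit and not a number: the limit of > 100000 nM in this assay, at which 1 of the 4 values shown sits. Among these compounds, this is the first swap at this position that clearly moves the result, with an at least 7.5-fold higher number from compound 3 to compound 4 (0.87 log units; beyond the scatter), an at least 4.4-fold higher number from compound 2 to compound 4 (0.64 log units; beyond the scatter) and an at least 13-fold higher number from compound 1 to compound 4 (1.11 log units; beyond the scatter), all three beyond the scatter and the last of them large. The trimethoxyphenyl and dichlorophenyl groups of compounds 1, 2 and 3 stay close together by comparison, so the position is not as forgiving as those compounds suggested, and exchanging one aryl group for another can cost most of the measured cytotoxicity on these cells.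

Among the compounds shown, the two bromines and the hydroxy group enter together, so it stays open whether the loss goes with the bromines, with the hydroxy group or only with the two combined. From the compounds shown here alone, a phenyl ring carrying just a hydroxy group, just bromine, or instead an amine or a carboxylic acid would help to separate these possibilities, and how any of them would read in this assay remains unknown.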